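The source may hold more compounds than are shown below. What is called first, only, known or untested is meant among the compounds shown, and "the series" means these compounds.

Measured so far in a functional assay on L02 cells (Homo sapiens) for inhibition, read by MTT assay, with a stated time of 48 h; a higher number here means a weaker inhibitor, a lower number a stronger inhibitor:

Compound 1 `COc1ccc2c(=O)c(/C=C/C(=O)Nc3ccc(Cl)cc3)coc2c1`. In this assay compound 1 gives > 200000 nM, which is a limit of the assay and not a number.
Compound 2 `COc1ccc(CNC(=O)/C=C/c2coc3cc(OC)ccc3c2=O)cc1`. In this assay compound 2 gives > 200000 nM, again a limit of the assay.
Compound 3 `COc1ccc2c(=O)c(/C=C/C(=O)NCc3ccccc3)coc2c1`. In this assay compound 3 gives > 200000 nM, also a limit of the assay.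

Compound 3 therefore stands nowhere on a numerical scale: its value is a limit only, and the same holds for the two other compounds shown, all three sitting at the limit of > 200000 nM in this assay, at which 3 of the 3 values shown sit. The steps among them, a step that the two limits leave unreadable from compound 1 to compound 2, a step that the two limits leave unreadable from compound 1 to compound 3 and a step that the two limits leave unreadable from compound 2 to compound 3, have no readable size for that reason.

Compound 4 `CCOc1ccc(NC(=O)/C=C/c2coc3cc(OC)ccc3c2=O)cc1` is the next compound to be measured. It differs from compound 3 by 4-ethoxyphenyl in place of benzyl on an amide-type nitrogen. The steps that touch the same place are those from compound 1 to compound 2 and from compound 1 to compound 3, both unreadable because the limit of > 200000 nM in this assay, at which 3 of the 3 values shown sit, holds every value shown. No direction or size of step can be drawn from them, so no step beyond the scatter is expected, and the most likely outcome is a further limit.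

The estimate for compound 4 in this assay is 200000 nM, within 100000 nM to 400000 nM, an expected step of a number no higher from compound 3 to compound 4 (the limit leaves the size open).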

Compound 4, half-maximal inhibitory concentration: > 200000 nM
Compound 4 ended at the assay's limit; the forecaster's own chance of this, stated with the estimate: 85%; the middle value lies on the limit itself.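

In this assay compound 4 gives > 200000 nM, a limit of the assay and not a number. No step from compound 1, compound 2 or compound 3 to compound 4 can be read, because all values share one limit: the limit of > 200000 nM in this assay, at which 4 of the 4 values shown sit.

The compounds shown leave open whether any group on the amide-type nitrogen of the shared core gives a numerical value in this assay.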